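Swapping a Cyclopentyl for a Methylbenzyl Arm

The source may report more compounds than this note shows. Statements on the series, on what has been measured and on what is new or still open speak of the compounds shown alone.

Compound 1 `CC1CCN(c2nc(C(F)(F)F)ccc2CNC(=O)C(c2ccc(NS(C)(=O)=O)c(F)c2)C2CCCC2)CC1` — 88.7 nM
Compound 2 `Cc1ccccc1C(C(=O)NCc1ccc(C(F)(F)F)nc1SC1CCCCC1)c1ccc(NS(C)(=O)=O)c(F)c1` — "active" (no number reported)
Compound 3 `CS(=O)(=O)Nc1ccc(C(Cc2ccccc2)C(=O)NCc2ccc(C(F)(F)F)nc2SC2CCCCC2)cc1F` — "active" (no number reported)

Within the data shown here, in an assay on CHO cells for antagonist activity at transient receptor potential cation channel subfamily V member 1 (Homo sapiens), read by FLIPR (a higher number here means a weaker inhibitor, a lower number a stronger inhibitor), compound 1 gives 88.7 nM, and it is the only compound with a number. Compound 2 is reported as "active" (no number reported), and compound 3 is reported as "active" (no number reported), with no figure for either. Compound 4 `Cc1ccc(CC(C(=O)NCc2ccc(C(F)(F)F)nc2N2CCC(C)CC2)c2ccc(NS(C)(=O)=O)c(F)c2)cc1` differs from compound 1 by one change: 4-methylbenzyl in place of cyclopentyl on a saturated chain carbon bound to an aromatic carbon and a carbonyl carbon. Among the measured compounds shown here, no step between two measured compounds is available, so the size of this change cannot be read from the data. That compound 2 and compound 3 are active suggests the core tolerates such groups. The step is expected to be small, within or just beyond the scatter, toward a slightly weaker inhibitor, as a 1.7-fold higher number from compound 1 to compound 4 (0.23 log units; within the scatter). Compound 4 is estimated at 150 nM, between 40 nM and 600 nM.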

Compound 4, inhibition constant: "active" (no number reported)
For compound 4 the study gives words and no number, and the estimate cannot be compared.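

Among these compounds, compound 4 is reported only as active, with no figure, so no step from compound 1 to compound 4 can be read. In this assay the compounds shown leave open how compound 2, compound 3 and compound 4 compare in strength with compound 1. No supporting evidence bears on this result.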